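Swapping the Hydroxyethyl Ring for a Methoxy Ring

The source may report more compounds than this note shows. Statements on the series, on what has been measured and on what is new or still open speak of the compounds shown alone.

In a functional assay on HeLa cells (Homo sapiens) for antiproliferative activity, read by cell counting, with a stated time of 3 days (on this read-out lower numbers stand for stronger inhibition and higher numbers for weaker inhibition), compound 3 `CC(Nc1ccccc1Oc1ccc(C(C)O)cc1)=C1C(=O)CC(c2ccccc2)CC1=O` gives 75 nM. Compound 2 `CC(Nc1ccccc1Oc1ccccc1)=C1C(=O)CC(c2ccccc2)CC1=O`, which has no substituent on the terminal ring, gives 79 nM, and the step of a 1.1-fold lower number from compound 2 to compound 3 (0.02 log units; within the scatter) lies within the scatter. Compound 1 `CC(Nc1ccccc1Oc1ccc(Cl)cc1)=C1C(=O)CC(c2ccccc2)CC1=O` gives 500 nM and stands apart from both, with steps of a 6.3-fold lower number from compound 1 to compound 2 (0.80 log units; beyond the scatter) and a 6.7-fold lower number from compound 1 to compound 3 (0.82 log units; beyond the scatter), each beyond the scatter.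

Compound 4 `COc1cccc(Oc2ccccc2NC(C)=C2C(=O)CC(c3ccccc3)CC2=O)c1` has 3-methoxyphenyl in place of 4-(1-hydroxyethyl)phenyl on an oxygen on an aromatic ring. Among the measured compounds shown here, no measured compound carries a methoxy group, so no step measures this change directly. The nearest guide is the step of a 1.1-fold lower number from compound 2 to compound 3 (0.02 log units; within the scatter), which shows a substituent leaving the number unchanged within the scatter, while the step of a 6.3-fold lower number from compound 1 to compound 2 (0.80 log units; beyond the scatter) shows that a substituent can cost a modest amount. A small move toward a higher number in this assay is therefore expected, possibly none beyond the scatter.

The estimated step is a 1.5-fold higher number from compound 3 to compound 4 (0.17 log units; within the scatter). Compound 4 is expected at 110 nM, with an estimated range from 35 nM to 350 nM.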

Compound 4, half-maximal inhibitory concentration: 93 nM
The estimate for compound 4 lay 1.2-fold (0.07 log units) above the measured number, and the stated range covers the measured number.
By their numbers in this assay, from the lowest: compounds 3, 2 and 4 (each within the scatter of the next); then compound 1.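

In this assay, the exchange of 4-(1-hydroxyethyl)phenyl for 3-methoxyphenyl on the oxygen gives a 1.2-fold higher number from compound 3 to compound 4 (0.09 log units; within the scatter), so the hydrogen-bond donor of the 1-hydroxyethyl group can be absent without a change beyond the scatter. Methoxy in place of hydrogen gives a 1.2-fold higher number from compound 2 to compound 4 (0.07 log units; within the scatter), which adds a second substituted terminal ring that stays within the scatter of the unsubstituted one. The chloro compound remains the exception among the compounds shown, and 3-methoxyphenyl in place of 4-chlorophenyl gives a 5.4-fold lower number from compound 1 to compound 4 (0.73 log units; beyond the scatter).

No measurement shown here explains why these terminal rings behave as they do. On these data alone, it remains open whether an amine, a carboxylic acid or a longer chain on this ring would also stay within the scatter of the unsubstituted compound, or would instead move the number as chloro does.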